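The source may report more compounds than this note shows. Statements on the series, on what has been measured and on what is new or still open speak of the compounds shown alone.

Measured compounds in an ADME assay on Vero cells (Chlorocebus sabaeus) for cytotoxicity, read by neutral red uptake, tested at 12.3 ug/mL; a higher number here means a weaker effect of the compound at the concentration tested, a lower number a stronger effect:
compound 1 `O=C1CSC(c2ccc(O)cc2)N1CCN1CCCCC1` gives 100%
compound 2 `COc1ccccc1C1SCC(=O)N1CCN1CCCCC1` gives 100%
compound 3 `O=C1CSC(c2ccccc2[N+](=O)[O-])N1CCN1CCCCC1` gives 100%

Compound 3 stands level with compounds 1 and 2 at the digits shown; all three readings lie within the scatter of one another, so none can be called weaker or stronger. The step to compound 4 `O=C1CSC(c2ccccc2Cl)N1CCN1CCCCC1` is chloro in place of nitro on an aromatic carbon. Among the compounds with values here, the only measured step that bears on it, no change at the digits printed from compound 2 to compound 3 (within the scatter), exchanged one group for another on an aromatic carbon and left the reading unchanged within the scatter. Within the data shown here, no measured step involves chloro. On this basis no change beyond the scatter is expected, and the expected step of no change at the digits printed from compound 3 to compound 4 (within the scatter) reflects that. Compound 4 is therefore estimated to give 100%, in a range from 88% to 100%.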

Compound 4, a percentage reported as activity, at one concentration (the size of the read-out at that concentration, not a potency): 100%
Compound 4: the middle estimate sits on the measured number at the digits printed; low and high end bracket the measured number.
By their numbers in this assay, from the lowest: compounds 1, 2, 3 and 4 (each within the scatter of the next).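

In this assay the step of no change at the digits printed from compound 3 to compound 4 (within the scatter) and the step of no change at the digits printed from compound 2 to compound 4 (within the scatter) show that a single chlorine atom on this aromatic carbon, ortho to a large group, reads the same as nitro or methoxy there. The step of no change at the digits printed from compound 1 to compound 4 (within the scatter) extends this sameness to a swap of whole aryl groups, with 2-chlorophenyl in place of 4-hydroxyphenyl on a saturated ring carbon.

As far as these compounds go, whether an amine or a carboxylic acid on this aromatic carbon would move the reading stays open. No evidence is available to explain the level readings.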